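This account rests on a few compounds, and the source may have more. Where it says the series, first, only, none or still open, it means among the compounds named here.

Compounds with results so far:
compound 1 `O=C(/C=C/c1ccc(N2CCCC2)cc1)c1ccc([N+](=O)[O-])cc1` — 77.6%
compound 3 `COc1cc(O)ccc1/C=C/C(=O)c1ccc(NC(C)=O)cc1` — 17.3%
compound 2 `COc1cc(O)ccc1/C=C/C(=O)c1ccc(N)cc1` — "not determined" (no result reported)

In an assay on isolated protein for inhibition of DNA topoisomerase 1 (Homo sapiens), tested at 20 uM (on this read-out lower numbers stand for a weaker effect and higher numbers for a stronger effect at the one concentration tested), compound 1 gives 77.6%, the higher of the two numbers obtained; the nearest, compound 3, gives 17.3%, a gap well beyond the scatter. Compound 2 has no number in this assay.

The step to compound 4 `O=C(/C=C/c1ccc(N2CCCC2)cc1)c1ccc(F)cc1` keeps the shared core of compound 1 and changes one group: fluoro in place of nitro on an aromatic carbon. Among the compounds with values here, no measured pair shows this change, so nothing comparable is available. The account expects a moderate drop, a number 22.6 percentage points lower from compound 1 to compound 4 (beyond the scatter), beyond the scatter but leaving compound 4 well above compound 3. Compound 4 is thus estimated at 55%, with a range from 30% to 80%.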

Compound 4, a percentage reported as inhibition, at one concentration (the size of the read-out at that concentration, not a potency): 73.1%
Beside the measured number, compound 4's estimate is 18.1 percentage points below it; measured number inside the range.
By their numbers in this assay, from the lowest: compound 3; then compounds 4 and 1 (each within the scatter of the next).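

In this assay, within the data shown here, the one step at this position, fluoro in place of nitro para to a large group, gives a number 4.5 percentage points lower from compound 1 to compound 4 (within the scatter) and so stays within the scatter. Among these compounds, the position therefore keeps its read-out when the three heavy atoms and two hydrogen-bond acceptors of nitro give way to a single fluorine, which the earlier compounds could not show. Nothing measured here explains why the two groups read alike. As far as these compounds go, it remains open how chloro, a nitrile or a carboxylic acid would read at this position.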